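A Second Chloro Group on the Aromatic Ring of Compound 1

The source may hold more compounds than are shown below. What is called first, only, known or untested is meant among the compounds shown, and "the series" means these compounds.

Measured compounds:
compound 1, `NC1=NC2(CCSCC2)N(OCCCOc2cccc(Cl)c2)C(N)=N1`, 130 nM
compound 2, `NC1=NC2(CCOCC2)N(OCCCOc2cccc(Cl)c2)C(N)=N1`, 1020 nM
compound 3, `NC1=NC2(CCOCC2)N(OCCCOc2ccc(Cl)c(Cl)c2)C(N)=N1`, 590 nM

In a functional assay on MDA-MB-231 cells (Homo sapiens) for antiproliferative activity, read by MTT assay, with a stated time of 72 h (on this read-out lower numbers stand for stronger inhibition and higher numbers for weaker inhibition), compound 1 gives 130 nM, the lowest of the three numbers. Compound 3 gives 590 nM and compound 2 gives 1020 nM; both of these steps from compound 1 lie beyond the scatter.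

Compound 4, `NC1=NC2(CCSCC2)N(OCCCOc2cccc(Cl)c2Cl)C(N)=N1`, differs from compound 1 by chloro in place of hydrogen on an aromatic carbon. Going by the values given here, the only measured step of the same kind is a 1.7-fold lower number from compound 2 to compound 3 (0.24 log units; within the scatter), where the chloro entered at another place on the ring and on the core shared by compounds 2 and 3 rather than that of compound 1. That step stayed within the scatter, so the evidence for adding a chloro is thin and points, if anywhere, to little change. The step expected in this assay from compound 1 to compound 4 is therefore small, with no clear direction: a 1.2-fold lower number from compound 1 to compound 4 (0.07 log units; within the scatter). Compound 4 is estimated to give 110 nM, within a range from 45 nM to 300 nM.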

Compound 4, half-maximal inhibitory concentration: 1 nM
Compound 4: the middle estimate sits 110-fold (2.04 log units) above what was measured; the whole stated range lies above it.
By their numbers in this assay, from the lowest: compound 4; then compound 1; then compounds 3 and 2 (each within the scatter of the next).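

Placing a chloro on the aromatic carbon ortho to the existing chloro group, which turns 3-chlorophenyl into 2,3-dichlorophenyl, gives a 130-fold lower number from compound 1 to compound 4 (2.11 log units; beyond the scatter) in this assay. This large step shows that this position on the ring of compound 1 can strongly affect inhibition, which the earlier chloro step gave no sign of. Adding a chloro therefore has no single effect across these compounds, as the two steps differ well beyond the scatter: the same change on two cores in this assay, a 1.7-fold lower number (0.24 log units; within the scatter) from compound 2 to compound 3 and a 130-fold lower number (2.11 log units; beyond the scatter) from compound 1 to compound 4, 75-fold (1.88 log units) apart, beyond the scatter of two such steps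

The compounds shown do not separate the place of the added chloro from the core that carries it, as the 2,3-dichlorophenyl group appears on one core only. On these data alone, it also remains open whether a bromo, a methyl or a methoxy group at this position would give a step of similar size.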